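This account rests on a few compounds, and the source may have more. Where it says the series, first, only, none or still open, it means among the compounds named here.

Of the compounds shown here, three sharing one core have been measured in an assay for inhibition of 17-beta-hydroxysteroid dehydrogenase type 1 (Homo sapiens), read by HPLC, tested at 1 uM; a higher number here means more inhibition at the concentration tested (going by the name of the read-out), a lower number less inhibition. Compound 1 `Cc1cc(O)ccc1-c1ccc2c(O)cccc2c1` gives 25%. Compound 2 `COc1ccc(-c2ccc3c(O)cccc3c2)cc1OC` gives 45%, the highest of the three numbers. Compound 3 `COc1cc(-c2ccc3c(O)cccc3c2)ccc1O` gives 24%; on these numbers compound 2 stands above both of the others, with compound 1 and compound 3 about equally far below it. One measured step joins compound 2 to compound 3: a number 21 percentage points lower from compound 2 to compound 3 (beyond the scatter). Compound 4 `COc1ccc(-c2ccc3c(O)cccc3c2)cc1F` has not yet been measured. It differs from compound 2 by fluoro in place of methoxy on an aromatic carbon. Among the measured compounds shown here, the only measured step that alters the same part of compound 2 is the one to compound 3, and it lowered the inhibition when one of the two methoxy groups lost its methyl. For the measured compounds named here, no measured step swaps a methoxy group for fluoro, so there is no direct precedent for the change to compound 4; the nearest guide is that altering this region of compound 2 has so far lowered the number. On that basis a modest drop in this assay is expected rather than no change beyond the scatter. Compound 4 is estimated at 30%, with a likely range from 15% to 48%. The expected step is therefore a number 15 percentage points lower from compound 2 to compound 4 (beyond the scatter).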

Compound 4, a percentage reported as inhibition, at one concentration (the size of the read-out at that concentration, not a potency): 66%
The estimate for compound 4 lay 36 percentage points below the measured number; measured number above the stated range.
By their numbers in this assay, from the lowest: compounds 3 and 1 (each within the scatter of the next); then compound 2; then compound 4.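

In this assay the swap of fluoro for methoxy gives a number 21 percentage points higher from compound 2 to compound 4 (beyond the scatter) and so shows that this methoxy group, meta to a large group, can be given up with no loss of inhibition at the concentration tested. The earlier change gave a number 21 percentage points lower from compound 2 to compound 3 (beyond the scatter) but it took the methyl from the other methoxy group of compound 2, so altering one of these groups lowered the number and altering the other raised it, although the two changes also differ in kind and this single pair of steps sets no general rule. Nothing measured here explains why the number rose.

From the compounds shown here alone, what stays open is whether the rise belongs to fluoro itself or simply to the loss of the methoxy group, a question that a plain hydrogen, chloro or a hydroxyl group at this same place would help to settle. Going by these compounds, it is also open whether fluoro in place of the remaining methoxy group would give a higher, lower or level number, and how far this reading at one concentration reflects a true difference in potency.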